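The compounds below may be only part of what the source reports. "The series", "measured", "known", "first", "only" and "open" are said of these compounds alone.

Measured compounds:
compound 1, `Cc1ccc(Cn2cc(CO/N=C/c3c(-c4ccc(F)cc4)nc4ccc(Br)cn34)nn2)cc1`, which in a functional assay on the whole organism (strain NMRI) with Mus musculus as the target, with a stated time of 4 h (a higher number here means that more compound is needed for the effect, a lower number that less compound is needed), gives 100 mg/kg;
compound 2, `COc1ccc(Cn2cc(CO/N=C/c3c(-c4ccccc4)nc4ccc(Br)cn34)nn2)cc1`, which gives 40 mg/kg;
compound 3, `O=[N+]([O-])c1ccc(Cn2cc(CO/N=C/c3c(-c4ccc(F)cc4)nc4ccc(Br)cn34)nn2)cc1`, which gives 100 mg/kg.

Compound 3 stands level with compound 1 at the top of the three numbers, while compound 2 shows a lower number than either. Compound 4, `O=[N+]([O-])c1ccc(Cn2cc(CO/N=C/c3c(-c4ccccc4)nc4ccc(Br)cn34)nn2)cc1`, differs from compound 3 in one place: hydrogen in place of fluoro on an aromatic carbon. For the measured compounds named here, no measured step carries this exact change. The step of no change at the digits printed from compound 1 to compound 3 (within the scatter) shows that nitro in place of methyl on an aromatic carbon leaves the number unchanged, so the remaining difference between compound 2 and compound 3, hydrogen in place of fluoro, is the likelier source of the gap between their values. Compound 4 is therefore expected to show a modest drop, a step of a 1.7-fold lower number from compound 3 to compound 4 (0.22 log units; within the scatter). The estimate for compound 4 is 60 mg/kg, with a range from 25 mg/kg to 150 mg/kg.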

Compound 4, minimum effective dose: 40 mg/kg
For compound 4 the middle estimate is 1.5-fold (0.18 log units) above the measured one, within the range that was stated.
By their numbers in this assay, from the lowest: compounds 2 and 4 (each within the scatter of the next); then compounds 1 and 3 (each within the scatter of the next).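

In this assay, for the compounds shown here, hydrogen in place of fluoro on the aromatic carbon para to a large group gives a 2.5-fold lower number from compound 3 to compound 4 (0.40 log units; beyond the scatter), the first direct reading of this change, and it lies beyond the scatter. Nitro in place of methoxy gives no change at the digits printed from compound 2 to compound 4 (within the scatter), so with phenyl present this exchange, like nitro in place of methyl with 4-fluorophenyl present, leaves the number level. Nothing available explains why removing the fluoro lowers the number.

The compounds shown leave open how an amine or a carboxylic acid at this same aromatic carbon would compare with hydrogen and fluoro.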